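A few compounds are considered here, and "the series" means these few. Any claim that something is new, unique, unknown or untested is made for them only; others in the source may bear on it.

Compound 1 `CC(C)(C)OC(=O)NCCNC(=O)CN1CN(c2ccccc2)C2(CCN(C(=O)c3ccc(C(C)(C)C)cc3)CC2)C1=O` gives 10900 nM in an assay on HEK293 cells for displacement of a labelled ligand from NPC1-like intracellular cholesterol transporter 1 (Homo sapiens); a higher number here means a weaker inhibitor, a lower number a stronger inhibitor.
Compound 2 `COC(=O)CCCNC(=O)CN1CN(c2ccccc2)C2(CCN(C(=O)c3ccc(C4CCCCC4)cc3)CC2)C1=O` gives 2500 nM in this assay.
Compound 3 `CC(C)(C)OC(=O)NCCCCNC(=O)CN1CN(c2ccccc2)C2(CCN(C(=O)c3ccc(C4CCCCC4)cc3)CC2)C1=O` gives 4600 nM in this assay.

Among the three measured compounds, compound 1 stands at the highest number, beyond the scatter from both compound 3 and compound 2. Among the measured compounds shown here, the only single-point comparison recorded among them is the one from compound 2 to compound 3, which gave a 1.8-fold higher number from compound 2 to compound 3 (0.26 log units; within the scatter) and so stays within the scatter; it concerns the end of the side chain that also changes here.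

Compound 4 `CC(C)(C)c1ccc(C(=O)N2CCC3(CC2)C(=O)N(CC(=O)NCCCCO)CN3c2ccccc2)cc1` has not been measured. It differs from compound 1 in one place: 2-hydroxyethyl in place of (tert-butoxycarbonyl)amino on a saturated chain carbon, two bonds along the chain from an amide-type nitrogen

The step from compound 2 to compound 3 is the only measured one that touches the end of this chain, and it was small. It does not involve a hydroxyl and does not involve compound 1's shared core with the tert-butyl group, so it is only a loose guide. On that basis a step of modest size and no clear direction is expected from compound 1 to compound 4, written as a 1.4-fold lower number from compound 1 to compound 4 (0.13 log units; within the scatter), and compound 4 is expected to give about 8000 nM, somewhere between 3000 nM and 25000 nM in this assay.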

Compound 4, half-maximal inhibitory concentration: 19200 nM
For compound 4 the middle estimate is 2.4-fold (0.38 log units) below the measured one; the range from low to high includes it.
By their numbers in this assay, from the lowest: compounds 2 and 3 (each within the scatter of the next); then compounds 1 and 4 (each within the scatter of the next).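

In this assay, putting 2-hydroxyethyl in place of (tert-butoxycarbonyl)amino, on a saturated chain carbon two bonds along the chain from an amide-type nitrogen, gives a 1.8-fold higher number from compound 1 to compound 4 (0.25 log units; within the scatter). Among the compounds shown here, this is the first reading at this chain end with a terminal hydroxyl and without either the carbamate or the ester, and it shows that a group of 8 heavy atoms can give way to one of 3 with no difference beyond the scatter, on the shared core of compound 1. The earlier step, a 1.8-fold higher number from compound 2 to compound 3 (0.26 log units; within the scatter), also stayed within the scatter but was read on a different core, so the two changes at this chain end now agree in that respect, though no evidence at hand explains the result.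

The compounds shown leave open whether an amine, a carboxylic acid or a longer chain at this end would move the number beyond the scatter. They also leave open what a 4-hydroxybutyl chain would give on the core of compound 2, which has the lowest number here at 2500 nM.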